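From 3-methoxybenzyl to ethyl on the shared core

The source may hold more compounds than are shown below. What is called first, only, known or untested is meant among the compounds shown, and "the series" means these compounds.

Measured in a functional assay on cells (Platelet, Homo sapiens) for inhibition; on this read-out higher numbers stand for weaker inhibition and lower numbers for stronger inhibition:
- compound 1 `CCOC(=O)c1ccc(-c2nn(Cc3ccccc3OC)c3ccccc23)cc1`: 470 nM
- compound 2 `CCOC(=O)c1ccc(-c2nn(Cc3cccc(OC)c3)c3ccccc23)cc1`: 260 nM

Compound 2 stands level with compound 1 within the scatter, and no other number is available yet. Next comes compound 3 `CCOC(=O)c1ccc(-c2nn(CC)c3ccccc23)cc1`, with methyl in place of 3-methoxyphenyl on a saturated chain carbon bound to an aromatic nitrogen. Going by the values given here, the sole measured step, a 1.8-fold lower number from compound 1 to compound 2 (0.26 log units; within the scatter), only swaps 2-methoxyphenyl for 3-methoxyphenyl. Among the compounds with values here, no measured compound lacks this ring. A higher number in this assay is the tentative expectation, with a wide range. The expected change is a 4.6-fold higher number from compound 2 to compound 3 (0.66 log units; beyond the scatter). For compound 3 the estimate is 1200 nM, ranging from 300 nM to 5000 nM.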

Compound 3, half-maximal inhibitory concentration: 360 nM
Compound 3: the middle estimate sits 3.3-fold (0.52 log units) above what was measured; the measured number falls inside the stated range.
By their numbers in this assay, from the lowest: compounds 2, 3 and 1 (each within the scatter of the next).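

In this assay the steps of a 1.4-fold higher number from compound 2 to compound 3 (0.14 log units; within the scatter) and a 1.3-fold lower number from compound 1 to compound 3 (0.12 log units; within the scatter) both stay within the scatter, so the methoxyphenyl ring on a saturated chain carbon bound to an aromatic nitrogen is not required for a number at this level. Compounds 1, 2 and 3 therefore show this position accepting both the 3-methoxybenzyl and the much smaller ethyl without a readable change. No evidence on the reason is at hand. As far as these compounds go, whether an amine, a carboxylic acid or a longer chain here would move the number beyond the scatter remains open.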